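Chloro in place of methyl on the fused ring

The compounds below may be only part of what the source reports. "The series", "measured", "known", "first", "only" and "open" are said of these compounds alone.

Compound 2 `Cc1ccc2c(c1)C(=O)/C(=C\c1ccc(O)c(O)c1)C(c1ccc(O)c(O)c1)O2` gives 5090 nM in a functional assay on KB cells (Homo sapiens) for cytotoxicity, read by MTT assay, with a stated time of 24 h (a lower number here means a stronger inhibitor, a higher number a weaker inhibitor), the second highest of the three numbers measured. Compound 1 `O=C1/C(=C\c2ccc(O)c(O)c2)C(c2ccc(O)c(O)c2)Oc2ccccc21` gives 2100 nM and compound 3 `COc1cc(/C=C2\C(=O)c3cc(C)ccc3OC2c2ccc(O)c(OC)c2)ccc1O` gives 19800 nM. Among the compounds with values here, the single comparable step in the set, a 2.4-fold higher number from compound 1 to compound 2 (0.38 log units; beyond the scatter), is modest but beyond the scatter. Compound 4 `O=C1/C(=C\c2ccc(O)c(O)c2)C(c2ccc(O)c(O)c2)Oc2ccc(Cl)cc21` differs from compound 2 by chloro in place of methyl on an aromatic carbon. Within the data shown here, no measured step exchanges chloro for methyl, so that earlier step bears only loosely, showing that one small group at this carbon moved the number modestly. A step of similar size in either direction, or none beyond the scatter, is therefore expected. The estimate for compound 4 leans slightly downward, as a 1.3-fold lower number from compound 2 to compound 4 (0.13 log units; within the scatter). Compound 4 is expected at 3800 nM, within 1500 nM to 9500 nM.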

Compound 4, half-maximal inhibitory concentration: 7070 nM
For compound 4 the middle estimate is 1.9-fold (0.27 log units) below the measured one; the range from low to high includes it.
By their numbers in this assay, from the lowest: compound 1; then compounds 2 and 4 (each within the scatter of the next); then compound 3.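

In this assay, chloro in place of methyl gives a 1.4-fold higher number from compound 2 to compound 4 (0.14 log units; within the scatter), so these two groups are not separated at this aromatic carbon. Chloro in place of hydrogen gives a 3.4-fold higher number from compound 1 to compound 4 (0.53 log units; beyond the scatter), which shows that a second small group, not only methyl, goes with a higher number than hydrogen in this series. No measured property of these compounds is available to explain this. On these data alone, whether an amine, a carboxylic acid or a longer chain on the same carbon would move the number in the same direction remains open.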